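Three Measured Analogues and an Unmeasured Fourth

The source may hold more compounds than are shown below. What is called first, only, known or untested is meant among the compounds shown, and "the series" means these compounds.

Of the compounds shown here, three have been measured in a functional assay on HepG2 cells (Homo sapiens) for cytotoxicity, read by MTT assay, with a stated time of 48 h; a lower number here means a stronger inhibitor, a higher number a weaker inhibitor. Compound 1 `CC1=NN(C(=O)CCc2ccccc2)C(c2cc(Br)cc(Br)c2O)C1` gives 9170 nM, and compound 2 `C=CCN(CC=C)CC(=O)N1N=C(C)CC1c1cc(Br)ccc1O` gives 7870 nM. Compound 3 `Cc1ccc(C(=O)N2N=C(c3cc4ccccc4oc3=O)CC2c2ccccc2)cc1` gives 52300 nM, the highest of the three numbers; its gaps to compound 1 and to compound 2 both lie beyond the scatter, so it is the weakest inhibitor among them. Compound 4 `CC(C)(C)NCC(=O)N1N=C(c2cc3ccccc3oc2=O)CC1c1ccccc1` has not been measured. It differs from compound 3 in one place: ((tert-butyl)amino)methyl in place of 4-methylphenyl on a carbonyl carbon. Going by the values given here, no pair of measured compounds shows this change, and neither compound 1 nor compound 2 differs from compound 3 in a single place, so nothing measured here speaks directly to its size. The step is expected to be a 1.5-fold lower number from compound 3 to compound 4 (0.17 log units; within the scatter), probably within the scatter and without a firm direction. Compound 4 is therefore estimated at 35000 nM, within 12000 nM to 100000 nM.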

Compound 4, half-maximal inhibitory concentration: 31400 nM
Compound 4: middle estimate off by 1.1-fold (0.05 log units), on the high side; low and high end bracket the measured number.
By their numbers in this assay, from the lowest: compounds 2 and 1 (each within the scatter of the next); then compounds 4 and 3 (each within the scatter of the next).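

In this assay, going by these compounds alone, the first single-place step reads a 1.7-fold lower number from compound 3 to compound 4 (0.22 log units; within the scatter) at the carbonyl carbon on the amide-type ring nitrogen. At this position, then, ((tert-butyl)amino)methyl, with no ring and with a hydrogen-bond donor, and 4-methylphenyl, with its aromatic ring and no donor, give numbers that cannot be told apart. No evidence on hand bears on the reason for this result.

As far as these compounds go, whether a carboxylic acid, a morpholine or a longer chain on this carbonyl carbon would also stay within the scatter of compound 3 remains open.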